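A few compounds are considered here, and "the series" means these few. Any claim that something is new, unique, unknown or untested is made for them only; others in the source may bear on it.

Working notes on the series. Among the measured compounds shown here, in a functional assay on MDA-MB-231 cells (Homo sapiens) for antiproliferative activity, read by sulforhodamine B assay, with a stated time of 72 h (a lower number here means a stronger inhibitor, a higher number a weaker inhibitor), compound 1 (`COc1cccc(/C=C2\CCC=CC2=O)c1`) gives 1060 nM and compound 2 (`COc1cccc(/C=C2\CCC=CC2=O)c1OC`) gives 610 nM, so compound 1 has only this one neighbour and the two values do not separate. Compound 3 (`CCOc1ccc(/C=C2\CCC=CC2=O)cc1OC`) is still unmeasured. It derives from compound 1 by a single change, ethoxy in place of hydrogen on an aromatic carbon, ortho to a methoxy group: ethoxy in place of hydrogen on an aromatic carbon. For the measured compounds named here, only one measured step bears on this change: a 1.7-fold lower number from compound 1 to compound 2 (0.24 log units; within the scatter). That step also replaces hydrogen on an aromatic carbon, but with methoxy and on a different carbon, so it is only an indirect guide. Going by the values given here, no measured compound carries ethoxy, and the effect of that group in this assay is therefore untested. With a single precedent that stays within the scatter, no step beyond the scatter is expected, and no direction can be favoured with confidence. The expected step is a 1.3-fold lower number from compound 1 to compound 3 (0.12 log units; within the scatter). Compound 3 is estimated at 800 nM, with an expected range of 320 nM to 2000 nM.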

Compound 3, half-maximal inhibitory concentration: 600 nM
Beside the measured number, compound 3's estimate is 1.3-fold (0.12 log units) above it; the measured number falls inside the stated range.
By their numbers in this assay, from the lowest: compounds 3, 2 and 1 (each within the scatter of the next).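

In this assay the step to ethoxy on this aromatic carbon, ortho to a methoxy group and para to a group of 8 heavy atoms, is a 1.8-fold lower number from compound 1 to compound 3 (0.25 log units; within the scatter) and so does not separate the two compounds, even with 3 heavy atoms added at this place. Compound 3 is the only compound shown with ethoxy, and its step joins a 1.7-fold lower number from compound 1 to compound 2 (0.24 log units; within the scatter) as a second replacement of hydrogen on the aromatic ring, on a different carbon and with a different group, so both replacements shown leave the number within the scatter of compound 1. No measurement at hand bears on what lies behind either step.

Still open, from the compounds shown here alone, is whether any group on this carbon can produce a step beyond the scatter: an amine, a carboxylic acid or a longer chain such as butoxy in the same place would test that. Methoxy on this same carbon would also show whether the ethyl part of ethoxy matters at all, a question that compound 3 alone cannot answer.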